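A few compounds are considered here, and "the series" means these few. Any claim that something is new, unique, unknown or untested is made for them only; others in the source may bear on it.

Three compounds built on the same core have numbers in a functional assay on KBVIN cells (Homo sapiens) for antiproliferative activity, read by sulforhodamine B assay, with a stated time of 3 days; a lower number here means that less compound is needed, a higher number that more compound is needed for the effect. Compound 1 `CCC1=C(O)c2c(oc(-c3ccc(OC)c(C)c3)cc2=O)C(CC)(CC)C1=O` gives 0.1 uM, compound 2 `CCC1=C(O)c2c(oc(-c3ccc(OC)c(Cl)c3)cc2=O)C(CC)(CC)C1=O` gives 1.37 uM, and compound 3 `CCC1=C(O)c2c(oc(-c3cc(C)c(O)c(C)c3)cc2=O)C(CC)(CC)C1=O` gives 8.9 uM, the highest number of the three. Compound 4 `CCC1=C(O)c2c(oc(-c3cc(C)ccc3F)cc2=O)C(CC)(CC)C1=O` has not yet been measured, and it differs from compound 3 as follows: 2-fluoro-5-methylphenyl in place of 4-hydroxy-3,5-dimethylphenyl on an aromatic carbon. The swap takes place on the aromatic carbon next to the ring oxygen.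

Among the compounds with values here, two measured steps bear directly on it, since both end in the group that compound 4 gives up. The large one is an 89-fold higher number from compound 1 to compound 3 (1.95 log units; beyond the scatter), and the modest one is a 6.5-fold higher number from compound 2 to compound 3 (0.81 log units; beyond the scatter). In both cases, the compound without the 4-hydroxy-3,5-dimethylphenyl group has the lower number. A third step, a 14-fold higher number from compound 1 to compound 2 (1.14 log units; beyond the scatter), shows that a single substituent on this aryl ring can also shift the number by a large amount. Within the data shown here, none of the measured compounds carries the 2-fluoro-5-methylphenyl group, so its own contribution remains unknown and the range must stay wide.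

A modest move to a lower number is expected, and the estimated step is a 3.6-fold lower number from compound 3 to compound 4 (0.55 log units; beyond the scatter). Compound 4 is therefore expected at 2.5 uM, with an estimated range from 0.4 uM to 12 uM.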

Compound 4, concentration for half-maximal effect: 3.24 uM
For compound 4 the middle estimate is 1.3-fold (0.11 log units) below the measured one; the measured number falls inside the stated range.
By their numbers in this assay, from the lowest: compound 1; then compound 2; then compound 4; then compound 3.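

On the aromatic carbon next to the ring oxygen, replacing the 4-hydroxy-3,5-dimethylphenyl group with a phenyl group carrying fluoro and methyl substituents and no hydrogen-bond donor gives, in this assay, a 2.7-fold lower number from compound 3 to compound 4 (0.44 log units; beyond the scatter) and so only partly closes the distance to the two compounds that carry a 4-methoxy group on the aryl ring. Measured against those two, the new group shows a 2.4-fold higher number from compound 2 to compound 4 (0.37 log units; beyond the scatter) and a 32-fold higher number from compound 1 to compound 4 (1.51 log units; beyond the scatter) so losing the 4-hydroxy-3,5-dimethylphenyl group is not enough on its own to reach the low numbers of compound 1 and compound 2, and the particular aryl group chosen still matters at this position. Nothing on hand explains why these aryl groups fall in this order.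

The compounds shown leave open what the fluoro and the methyl substituents of compound 4 each contribute, as the two appear only together and the 4-methoxy group is absent from that compound. They also leave open how an aryl ring bearing an amine, a carboxylic acid or a trifluoromethyl group would behave on this carbon.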